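The compounds below may be only part of what the source reports. "The series", "measured", "known", "first", "only" and "open" are said of these compounds alone.

Compound 3 `CCCCCCCCNc1n[n+]([O-])c2ccccc2[n+]1[O-]` bears a long saturated chain on a nitrogen on an aromatic ring of the shared core. In a functional assay on PC-3 cells (Homo sapiens) for cytotoxicity, read by MTT assay, with a stated time of 48 h (on this read-out higher numbers stand for weaker inhibition and lower numbers for stronger inhibition), compound 3 gives 18200 nM, a number lying within the usual scatter of both compound 1 `[O-][n+]1nc(NC2CC2)[n+]([O-])c2ccccc21`, which gives 15900 nM, and compound 2 `[O-][n+]1nc(NC2CCCCC2)[n+]([O-])c2ccccc21`, which gives 10500 nM. Compound 4 `C=CCNc1n[n+]([O-])c2ccccc2[n+]1[O-]` differs from compound 3 by vinyl in place of heptyl on a saturated chain carbon bound to a nitrogen on an aromatic ring. For the measured compounds named here, the only measured step between neighbours, a 1.5-fold lower number from compound 1 to compound 2 (0.18 log units; within the scatter), exchanges one ring on that nitrogen for another and does not bear directly on shortening a chain. Since three quite different groups on that nitrogen all fall within the scatter of one another, no step beyond the scatter is expected for a 1.1-fold lower number from compound 3 to compound 4 (0.06 log units; within the scatter). Compound 4 is therefore estimated at 16000 nM, with a range from 7000 nM to 36000 nM.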

Compound 4, half-maximal inhibitory concentration: > 56000 nM
Compound 4: a limit, no number (the forecaster's own chance of this, stated with the estimate: 10%); middle value at least 3.5-fold (0.54 log units) away from the limit.
By their numbers in this assay, from the lowest: compounds 2, 1 and 3 (each within the scatter of the next). At a limit, above all of these: compound 4.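

In this assay compound 4 reads only as a limit of the assay, not as a number: the limit of > 56000 nM in this assay, at which 1 of the 4 values shown sits. The three earlier groups on a nitrogen on an aromatic ring left their numbers within the scatter of one another, whereas allyl departs from all of them, with an at least 3.0-fold higher number from compound 3 to compound 4 (0.48 log units; beyond the scatter), an at least 5.3-fold higher number from compound 2 to compound 4 (0.72 log units; beyond the scatter) and an at least 3.5-fold higher number from compound 1 to compound 4 (0.54 log units; beyond the scatter). This position therefore does respond to the group it carries, and vinyl in place of heptyl is enough to show it.

The compounds shown do not separate the shorter chain from the double bond, which a saturated propyl chain on that nitrogen would do. As far as these compounds go, how a benzyl group there would read also stays open.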